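This account rests on a few compounds, and the source may have more. Where it says the series, first, only, none or still open, it means among the compounds named here.

For the measured compounds named here, compound 2 `NS(=O)(=O)CCCNc1nonc1/C(=N/O)Nc1ccc(F)c(Br)c1` gives 15 nM in an assay on HeLa cells for inhibition of Indoleamine 2,3-dioxygenase 1 (Homo sapiens), read by spectrophotometry, with a stated time of 24 h (a lower number here means that less compound is needed, a higher number that more compound is needed for the effect), the lowest of the two numbers measured so far; compound 1 `CCNS(=O)(=O)CCNc1nonc1/C(=N/O)Nc1ccc(F)c(Br)c1` gives 41 nM. Going by the values given here, the only step measured between them, a 2.7-fold lower number from compound 1 to compound 2 (0.44 log units; beyond the scatter), altered the sulfamoyl end of the chain and nothing else.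

Compound 3 `NS(=O)(=O)CCONc1nonc1/C(=N/O)Nc1ccc(F)c(Br)c1` differs from compound 2 in the chain that joins the sulfamoyl group to the core: 2-sulfamoylethoxy in place of 3-sulfamoylpropyl on a nitrogen on an aromatic ring. An oxygen takes the place of a chain carbon, so the chain keeps its length while the atom attached to the ring nitrogen changes. Among the compounds with values here, no measured step touches this part of the molecule; the step from compound 1 to compound 2 concerns the far end of the chain, not its attachment to the ring, so it gives no direct guidance here. The expectation therefore rests on compound 2 alone and carries wide uncertainty, and the most likely outcome is judged to be a step of about a 1.7-fold higher number from compound 2 to compound 3 (0.22 log units; within the scatter), which would stay within the scatter. Compound 3 is expected to give about 25 nM, with a plausible range from 8 nM to 80 nM.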

Compound 3, half-maximal effective concentration: 27 nM
The estimate for compound 3 lay 1.1-fold (0.03 log units) below the measured number; measured number inside the range.
By their numbers in this assay, from the lowest: compounds 2, 3 and 1 (each within the scatter of the next, the first and the last beyond it).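

In this assay the oxygen can take the place of a chain carbon on this ring nitrogen without a clear shift, with a 1.8-fold higher number from compound 2 to compound 3 (0.26 log units; within the scatter): the 2-sulfamoylethoxy and 3-sulfamoylpropyl chains cannot be told apart by this read-out. The comparison with the 2-(ethylsulfamoyl)ethyl chain also stays inside the scatter, with a 1.5-fold lower number from compound 1 to compound 3 (0.18 log units; within the scatter), so compound 3 cannot be separated from compound 1 either, even though compound 1 and compound 2 do stand apart beyond the scatter; compound 3 therefore sits between two compounds that differ without being distinguishable from either one. No measurement is available that could account for how little the number moves with this exchange of atoms.

The 2-sulfamoylethoxy chain is the only chain of its kind here, so a small real effect of the oxygen cannot be separated from the scatter. From the compounds shown here alone, it remains open whether the oxygen would be accepted as readily in a longer chain, or in a chain ending in a carboxylic acid or an amine instead of the sulfamoyl group.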